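Amide side chain: dimethylcyclopentyl replaced by neopentyl

The compounds below may be only part of what the source reports. "The series", "measured", "known", "first", "only" and "open" are said of these compounds alone.

Compound 1 `CCCCc1noc(-c2ccc(C(=O)NC[C@@H]3CCCC3(C)C)cc2)n1` is the reference. In an assay for activation of potassium voltage-gated channel subfamily KQT member 1 (Cavia porcellus) (a lower number here means a stronger inhibitor, a higher number a weaker inhibitor), compound 1 gives 9 nM, the lowest of the two single numbers in the set. Compound 2 `CC(C)(C)CCNC(=O)c1ccc(-n2ccc3ccccc32)cc1`, which carries a neopentyl amide with a different aryl group, gives 260 nM, a much higher number than compound 1. Compound 3 `CC1(C)CCCC1CNC(=O)c1ccc(-c2nc(CC3CC3)no2)cc1` has been run more than once, (the several entries of compound 3 in this assay, 18 nM; 23 nM (2 entries)), and its entries, 18 nM; 23 nM (2 entries), sit close together. Compound 4 `CCCCc1noc(-c2ccc(C(=O)NCCC(C)(C)C)cc2)n1` differs from compound 1 by a group of 5 heavy atoms (5 carbon; no ring) in place of a group of 7 heavy atoms (7 carbon; one five-membered non-aromatic ring of carbon only), on a saturated chain carbon bound to an amide-type nitrogen. Among the measured compounds shown here, no measured pair isolates this change. The number is expected to rise, with a 6.7-fold higher number from compound 1 to compound 4 (0.82 log units; beyond the scatter) likely beyond the scatter. Compound 4 is expected at 60 nM, within 15 nM to 250 nM.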

Compound 4, half-maximal inhibitory concentration: 23 nM
Beside the measured number, compound 4's estimate is 2.6-fold (0.42 log units) above it, and the stated range covers the measured number.
By their numbers in this assay, from the lowest: compound 1; then compound 4; then compound 2.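

In this assay, among the compounds shown here, a 2.6-fold higher number from compound 1 to compound 4 (0.41 log units; beyond the scatter) gives the first direct reading at this place on the amide side chain. Neopentyl in place of the ring-bearing group removes the five-membered ring and the defined stereocentre, and the rise is only modest, so the ring is not essential for a low number. Nothing shown gives a cause for this step. The separate contributions of the ring and the stereocentre remain unresolved. Going by these compounds, how a cyclohexyl ring, a longer chain or an amine would behave at this place also remains open.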